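A few compounds are considered here, and "the series" means these few. Any claim that something is new, unique, unknown or untested is made for them only; others in the source may bear on it.

In a functional assay on PC-3 cells (Homo sapiens) for cytotoxicity, read by MTT assay, with a stated time of 72 h (a lower number here means a stronger inhibitor, a higher number a weaker inhibitor), compound 1 (`CNC(=O)c1cc(Oc2ccc(C(=O)/C=C/c3ccc(F)cc3Cl)cc2)ccn1`) gives 4760 nM and compound 2 (`CNC(=O)c1cc(Oc2ccc(C(=O)/C=C/c3ccccc3)cc2)ccn1`) gives 3170 nM while compound 3 (`CNC(=O)c1cc(Oc2ccc(C(=O)/C=C/c3ccc(F)cc3)cc2)ccn1`) gives 6140 nM and so stands within the scatter of both. Compound 4 (`CNC(=O)c1cc(Oc2ccc(C(=O)/C=C/c3ccc(Cl)cc3Cl)cc2)ccn1`) departs from compound 3 in one place (2,4-dichlorophenyl in place of 4-fluorophenyl on a double-bonded chain carbon bound to a double-bonded chain carbon) and awaits measurement. Going by the values given here, three measured steps bear on this change. Hydrogen in place of chloro gives a 1.3-fold higher number from compound 1 to compound 3 (0.11 log units; within the scatter) and fluoro in place of hydrogen gives a 1.9-fold higher number from compound 2 to compound 3 (0.29 log units; within the scatter) while phenyl in place of 2-chloro-4-fluorophenyl gives a 1.5-fold lower number from compound 1 to compound 2 (0.18 log units; within the scatter) and each stays within the scatter. Among the compounds with values here, no measured step exchanges fluoro for chloro. The expected change is a 1.4-fold lower number from compound 3 to compound 4 (0.13 log units; within the scatter) and so no step beyond the scatter is expected in this assay here. Compound 4 is estimated at 4500 nM with an expected range from 2500 nM to 8000 nM for now.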

Compound 4, half-maximal inhibitory concentration: 9220 nM
Estimate against measurement, compound 4: 2.0-fold (0.31 log units) below, outside the stated range (above it).
By their numbers in this assay, from the lowest: compounds 2, 1, 3 and 4 (each within the scatter of the next, the first and the last beyond it).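

In this assay, going by these compounds alone, 2,4-dichlorophenyl in place of phenyl gives the first step beyond the scatter at this place, a 2.9-fold higher number from compound 2 to compound 4 (0.46 log units; beyond the scatter), though it is a modest one. Against the two other halogenated compounds the change stays within the scatter, both for 2,4-dichlorophenyl in place of 4-fluorophenyl, a 1.5-fold higher number from compound 3 to compound 4 (0.18 log units; within the scatter), and for chloro in place of fluoro, a 1.9-fold higher number from compound 1 to compound 4 (0.29 log units; within the scatter). Nothing available accounts for the step to 2,4-dichlorophenyl. Open, as far as these compounds go, is how 4-chlorophenyl or 2-chlorophenyl would stand at this place, which would show whether one chloro alone carries the step. Also open, from the compounds shown here alone, is how a methoxy group or an amine on the ring would read here.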